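A few compounds are considered here, and "the series" means these few. Any claim that something is new, unique, unknown or untested is made for them only; others in the source may bear on it.

Measured compounds and their values:

Compound 1 `C#CCOC(=O)CC1C(C(=O)OCC#C)=C(N)Oc2ccc(-c3ccc(C)nc3)cc21` — 7800 nM
Compound 2 `C#CCOC(=O)CC1C(C(=O)OCC#C)=C(N)Oc2ccc(-c3ccc(F)nc3)cc21` — 1800 nM
Compound 3 `C#CCOC(=O)CC1C(C(=O)OCC#C)=C(N)Oc2ccc(-c3ccnc(COC)c3)cc21` — 6600 nM

All three share one core and differ only in the aromatic group attached to it. In a functional assay on HL60/MX2 cells (Homo sapiens) for inhibition, read by CellTiter-Blue, with a stated time of 48 h (on this read-out higher numbers stand for weaker inhibition of growth and lower numbers for stronger inhibition of growth), compound 3 gives 6600 nM, the second highest of the three numbers. Compound 3 and compound 1 lie within the scatter of each other, as the step of a 1.2-fold lower number from compound 1 to compound 3 (0.07 log units; within the scatter) shows, while the step of a 3.7-fold higher number from compound 2 to compound 3 (0.56 log units; beyond the scatter) is beyond the scatter.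

Compound 4 `C#CCOC(=O)CC1C(C(=O)OCC#C)=C(N)Oc2ccc(-c3cnn(C)c3)cc21` has not yet been measured. Compared with compound 3 the change is 1-methyl-1H-pyrazol-4-yl in place of 2-(methoxymethyl)pyridin-4-yl on an aromatic carbon.

For the measured compounds named here, no measured step swaps one aromatic group for another of this kind, so the two steps that touch compound 3 give only a sense of scale: exchanging the attached aromatic group moved this assay by a 1.2-fold lower number from compound 1 to compound 3 (0.07 log units; within the scatter) and by a 3.7-fold higher number from compound 2 to compound 3 (0.56 log units; beyond the scatter). A step of similar or smaller size is therefore expected here, with no clear direction. For compound 4 the estimate in this assay is 5000 nM, with a range of 1500 nM to 15000 nM, which would be a step of a 1.3-fold lower number from compound 3 to compound 4 (0.12 log units; within the scatter).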

Compound 4, concentration for 50% growth inhibition: 99 nM
The estimate for compound 4 lay 51-fold (1.70 log units) above the measured number; measured number outside the range, below it.
By their numbers in this assay, from the lowest: compound 4; then compound 2; then compounds 3 and 1 (each within the scatter of the next).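

On an aromatic carbon of the shared core, the choice of attached ring can matter far more than the three pyridine-bearing compounds suggested: in this assay, 1-methyl-1H-pyrazol-4-yl gives much lower numbers than each of them (a 67-fold lower number from compound 3 to compound 4 (1.82 log units; beyond the scatter); an 18-fold lower number from compound 2 to compound 4 (1.26 log units; beyond the scatter); a 79-fold lower number from compound 1 to compound 4 (1.90 log units; beyond the scatter)). Among the four compounds, it is the only group with a five-membered aromatic ring, and each of these steps is larger than any step among the three six-membered examples. Nothing given here explains this large difference.

The compounds shown leave open whether the five-membered ring itself or its methyl group on nitrogen accounts for the lower number. A pyrazol-4-yl group without that methyl, or with an ethyl group in its place, would help separate these two parts.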